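Chloro to fluoro on a small aromatic amide

This account rests on a few compounds, and the source may have more. Where it says the series, first, only, none or still open, it means among the compounds named here.

In a functional assay on KG-1 cells (Homo sapiens) for cytotoxicity, read by luminescence and CellTiter-Glo, with a stated time of 3 days (a lower number here means a stronger inhibitor, a higher number a weaker inhibitor), compound 1 `O=C(Nc1ccc(C(F)(F)F)cc1)c1cc(Br)c(F)cc1O` gives 820 nM as its result, and compound 2 `O=C(Nc1ccc(C(F)(F)F)cc1)c1ccc(Cl)cc1O` gives 580 nM as its result. These two numbers lie within the usual scatter of each other, so compound 2 stands level with compound 1 so far. Compound 3 `O=C(Nc1ccc(C(F)(F)F)cc1)c1ccc(F)cc1O` differs from compound 2 in one place (fluoro in place of chloro on an aromatic carbon): fluoro in place of chloro on an aromatic carbon. For the measured compounds named here, no measured pair shows this swap directly. Set against compound 2, from which it differs in more than one place, compound 1 gives 820 nM here, so only a small step towards a higher number is expected in this assay and it may stay within the scatter. The estimate means a 1.6-fold higher number from compound 2 to compound 3 (0.19 log units; within the scatter) as the expected step. Compound 3 is estimated at 900 nM (expected range 350 nM to 2500 nM).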

Compound 3, half-maximal inhibitory concentration: 740 nM
For compound 3 the middle estimate is 1.2-fold (0.09 log units) above the measured one, within the range that was stated.
By their numbers in this assay, from the lowest: compounds 2, 3 and 1 (each within the scatter of the next).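

In this assay, fluoro in place of chloro on this aromatic carbon, meta to a hydroxy group and para to a large group, gives a 1.3-fold higher number from compound 2 to compound 3 (0.11 log units; within the scatter), so the two halogens stand level at this position. Hydrogen in place of bromo gives a 1.1-fold lower number from compound 1 to compound 3 (0.04 log units; within the scatter), so removing the bromo of compound 1 also leaves compound 3 level with it, and neither single-atom swap separates these compounds. Nothing measured here explains either step.

Still open, from the compounds shown here alone, is whether a different kind of group on this carbon, such as an amine, a carboxylic acid or a longer chain, would give a step beyond the scatter. Going by these compounds, the hydroxy group and the trifluoromethyl group are the same in all three compounds, so their part in the activity also remains unknown.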